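Anilide Swap on a Triazole Ether Scaffold

A few compounds are considered here, and "the series" means these few. Any claim that something is new, unique, unknown or untested is made for them only; others in the source may bear on it.

Measured compounds:
- compound 1 `Cc1ccc([N+](=O)[O-])cc1NC(=O)Cn1cc(COc2ccc3c(c2)CCC3)nn1`: "not determined" (no result reported) in an ADME assay on HEK293 cells (Homo sapiens) for inhibition, read by MTT assay, with a stated time of 48 h, tested at 25 uM; on this read-out lower numbers stand for less inhibition and higher numbers for more inhibition at the one concentration tested (going by the name of the read-out)
- compound 2 `Cc1cccc(-n2cc(COc3ccc4c(c3)CCC4)nn2)c1`: 23.4%

In this assay compound 2 gives 23.4%, a modest read-out at the single concentration used. For compound 1 the same assay returned "not determined" (no result reported), so compound 1 stands nowhere on the scale shown; only the absence of a result is known for it.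

Compound 3 `COc1ccccc1NC(=O)Cn1cc(COc2ccc3c(c2)CCC3)nn1` differs from compound 1 by 2-methoxyphenyl in place of 2-methyl-5-nitrophenyl on an amide-type nitrogen. With no number for compound 1, the step from compound 1 to compound 3 in this assay cannot be given a size or direction from the data; it may well lie within the scatter, but that is not established. Going by the values given here, the only anchor is compound 2, whose read-out is modest.

On that basis compound 3 is expected to give about 20% in this assay, estimated to fall between 5% and 40%.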

Compound 3, a percentage reported as inhibition, at one concentration (the size of the read-out at that concentration, not a potency): 23.4%
The estimate for compound 3 lay 3.4 percentage points below the measured number, and the stated range covers the measured number.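

Going by these compounds alone, compound 1 has no number in this assay, so no step from it to compound 3 can be read. No supporting data bear on the result for compound 3. The compounds shown leave open whether 2-methoxyphenyl in place of 2-methyl-5-nitrophenyl alters this read-out at all.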